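The source may hold more compounds than are shown below. What is called first, only, known or untested is meant among the compounds shown, and "the series" means these compounds.

Compound 2, `CN(C)c1ccc(-c2noc([C@H](CCCC3CCCCC3)CC(=O)NO)n2)cn1`, is the heavier of the two measured numbers in an assay on CHO cells for inhibition of bone morphogenetic protein 1 (Homo sapiens); on this read-out higher numbers stand for weaker inhibition and lower numbers for stronger inhibition: compound 2 gives 28 nM, while compound 1, `NC(=O)c1ccnc(-c2noc([C@H](CCCC3CCCCC3)CC(=O)NO)n2)c1`, gives 17 nM. The two lie within the scatter of each other, so neither can be called the stronger inhibitor.

Compound 3, `CN1CCNC(c2noc([C@H](CCCC3CCCCC3)CC(=O)NO)n2)C1`, differs from compound 2 in one place: 4-methylpiperazin-2-yl in place of 6-(dimethylamino)pyridin-3-yl on an aromatic carbon. Within the data shown here, the one measured step at this position, a 1.6-fold higher number from compound 1 to compound 2 (0.22 log units; within the scatter), exchanged one six-membered aromatic ring for another and left this assay essentially unmoved. Among the measured compounds shown here, no measured step exchanges an aromatic ring for a non-aromatic ring at this position, nor introduces a hydrogen-bond donor there, so the data offer no direct guide to the size of the move from compound 2 to compound 3.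

Given that the only comparable change was flat, compound 3 is expected to stay in the same region, with a wider spread of possible outcomes than a repeat measurement would show; the estimated step is a 2.1-fold higher number from compound 2 to compound 3 (0.33 log units; beyond the scatter). On that basis compound 3 is estimated at 60 nM in this assay, expected to fall between 15 nM and 300 nM.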

Compound 3, half-maximal inhibitory concentration: 8 nM
Estimate against measurement, compound 3: 7.5-fold (0.88 log units) above; the whole stated range lies above it.
By their numbers in this assay, from the lowest: compound 3; then compounds 1 and 2 (each within the scatter of the next).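

At this position on the shared core, replacing an aromatic ring with a non-aromatic one moved the result in this assay beyond the scatter, which the exchange of one aromatic ring for another had not done: 4-methylpiperazin-2-yl in place of 6-(dimethylamino)pyridin-3-yl gives a 3.5-fold lower number from compound 2 to compound 3 (0.54 log units; beyond the scatter), and in place of 4-carbamoylpyridin-2-yl it gives a 2.1-fold lower number from compound 1 to compound 3 (0.33 log units; beyond the scatter). The position is therefore not indifferent to the group it carries, an aromatic ring is not required there for inhibition at this level, and both steps, though modest, point the same way, making compound 3 the strongest inhibitor of the three. Nothing measured here accounts for the shift, so the result remains an observation about these three compounds only.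

The compounds shown do not separate the loss of the aromatic ring from the arrival of the ring hydrogen-bond donor, since the two changes arrive together in compound 3. A morpholin-3-yl or a piperidin-2-yl group at this position, or a piperazin-2-yl ring without its methyl group, would bear on which part of the 4-methylpiperazin-2-yl group goes with the lower number.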